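The source may hold more compounds than are shown below. What is called first, only, known or untested is meant among the compounds shown, and "the series" means these compounds.

Compound 1 `CC(Sc1nnc(-c2ccncc2)s1)C(=O)NCc1ccccc1Cl`: in an ADME assay on HepG2 cells (Homo sapiens) for cytotoxicity, with a stated time of 3 days (a higher number here means that more compound is tolerated, a lower number that less compound is tolerated), compound 1 reaches only the limit > 50000 nM.
Compound 2 `CC(Sc1nnc(-c2ccncc2)s1)C(=O)Nc1ccc(Cl)cc1`: in this assay compound 2 likewise reaches only the limit > 50000 nM.
Compound 3 `CC(CSc1nnc(-c2ccncc2)s1)C(=O)NCc1ccccc1Cl`: in this assay compound 3 also reaches only the limit > 50000 nM.

The change from compound 1 to compound 2 is 4-chlorophenyl in place of 2-chlorobenzyl on an amide-type nitrogen. The step that the two limits leave unreadable from compound 1 to compound 2 cannot be read, because of the limit of > 50000 nM in this assay, at which 3 of the 3 values shown sit. Compound 4 `CC(CSc1nnc(-c2ccncc2)s1)C(=O)Nc1ccc(Cl)cc1` is not yet measured; it differs from compound 3 by 4-chlorophenyl in place of 2-chlorobenzyl on an amide-type nitrogen, the same change at the same place. How the core of compound 3 differs from the core of compound 1 is not broken down here.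

For compound 4 the step that the limit leaves unreadable from compound 3 to compound 4 is expected to be too small to read, which rests on the fact that (the limit of > 50000 nM in this assay, at which 3 of the 3 values shown sit). Compound 4 is therefore estimated to show 60000 nM in this assay, most likely again as a limit.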

Compound 4, half-maximal cytotoxic concentration: > 50000 nM
Compound 4 gave a limit, no number (the forecaster's own chance of this, stated with the estimate: 85%); the middle value does not contradict the limit.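

No step can be read from compound 3 to compound 4, since both values are limits and not numbers: the limit of > 50000 nM in this assay, at which 4 of the 4 values shown sit. The compounds shown leave open at what concentration any of them harms the cells in this assay, and whether 4-chlorophenyl in place of 2-chlorobenzyl changes that concentration.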